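Methoxy for hydroxy on the dichlorophenyl urea

The source may hold more compounds than are shown below. What is called first, only, known or untested is meant among the compounds shown, and "the series" means these compounds.

Compound 2 `O=C(Nc1cccc(-n2cc(-c3ccncc3)c(-c3cc(O)cc(Cl)c3)n2)c1)Nc1ccc(Cl)c(Cl)c1` gives -12% in a functional assay on IGROV-1 cells (Homo sapiens) for inhibition, read by sulforhodamine B assay, with a stated time of 48 h, tested at 100 uM (a lower number here means a stronger effect, a higher number a weaker effect of the compound at the concentration tested), the highest of the three numbers recorded. Compound 1 `O=C(Nc1cccc(-n2cc(-c3ccncc3)c(-c3cc(O)cc(Cl)c3)n2)c1)Nc1ccc(Cl)c(C(F)(F)F)c1` gives -41% and compound 3 `COc1cc(Cl)cc(-c2nn(-c3cccc(NC(=O)Nc4cc(C(F)(F)F)cc(C(F)(F)F)c4)c3)cc2-c2ccncc2)c1` gives -42%; both stand beyond the scatter below compound 2. Going by the values given here, the only single-point step recorded, a number 29 percentage points higher from compound 1 to compound 2 (beyond the scatter), concerns a different position and does not bear on the change to compound 4 `COc1cc(Cl)cc(-c2nn(-c3cccc(NC(=O)Nc4ccc(Cl)c(Cl)c4)c3)cc2-c2ccncc2)c1`, which is methyl in place of hydrogen on an oxygen on an aromatic ring. Among the compounds with values here, compounds 1 and 3 differ in two places, so their values show only that the methoxy compound and the hydroxy compound reach similar numbers. Within the data shown here, no measured pair isolates this change. The step of a number 8 percentage points lower from compound 2 to compound 4 (within the scatter) is therefore expected to be small and of uncertain direction. Compound 4 is estimated at -20%, range -45% to 5%.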

Compound 4, a percentage reported as activity, at one concentration (the size of the read-out at that concentration, not a potency): 8%
Compound 4: the middle estimate sits 28 percentage points below what was measured; measured number outside the range, above it.
By their numbers in this assay, from the lowest: compounds 3 and 1 (each within the scatter of the next); then compound 2; then compound 4.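

Going by these compounds alone, with the urea side held fixed, the step of a number 20 percentage points higher from compound 2 to compound 4 (beyond the scatter) in this assay is the first reading that isolates this oxygen: methyl in place of hydrogen gives a weaker effect at the concentration tested. The position therefore responds to this change, at least with the urea side of compound 2. Nothing measured here accounts for the step. 

As far as these compounds go, it remains open whether the same step holds with the urea sides of compound 1 and compound 3. Also open, from the compounds shown here alone, is how an amine in place of the hydroxy group, or a longer ether chain on this oxygen, would read.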